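The source may hold more compounds than are shown below. What is called first, only, known or untested is meant among the compounds shown, and "the series" means these compounds.

Measured compounds:
Compound 1, `COc1ccc(F)cc1CNCCCNc1ccnc2cc(Cc3ccc(C#N)cc3)ccc12`: 4200 nM
Compound 2, `COc1ccc(F)cc1CNCCCNc1ccnc2cc(Oc3ccc(C(C)(C)C)cc3)ccc12`: 14500 nM

For the measured compounds named here, in a physicochemical assay for solubility, with a stated time of 18 h, at pH 7.4 (on this read-out lower numbers stand for lower solubility and higher numbers for higher solubility), compound 2 stands highest of the two numbers so far; its nearest neighbour is compound 1, and the step of a 3.5-fold higher number from compound 1 to compound 2 (0.54 log units; beyond the scatter) lies beyond the scatter. Compound 3, `COc1ccc(F)cc1CNCCCNc1ccnc2cc(Oc3ccccc3OC)ccc12`, has not yet been measured in this assay. It differs from compound 2 by 2-methoxyphenyl in place of 4-(tert-butyl)phenyl on an oxygen on an aromatic ring. Going by the values given here, the only measured step, from compound 1 to compound 2, changes the same part of the shared core, but it exchanges a 4-cyanobenzyl for a 4-(tert-butyl)phenoxy and so does not match the present change; no measured step covers 4-(tert-butyl)phenyl giving way to 2-methoxyphenyl. That earlier step shows this position can move the number modestly, so a step of comparable size in either direction, or none beyond the scatter, is expected. Compound 3 is estimated at 12000 nM, within 4000 nM to 40000 nM. The step of a 1.2-fold lower number from compound 2 to compound 3 (0.08 log units; within the scatter) is therefore the expected outcome.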

Compound 3, solubility: 14500 nM
The estimate for compound 3 lay 1.2-fold (0.08 log units) below the measured number; low and high end bracket the measured number.
By their numbers in this assay, from the lowest: compound 1; then compounds 2 and 3 (each within the scatter of the next).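

In this assay, replacing 4-(tert-butyl)phenyl with 2-methoxyphenyl on the oxygen gives no change at the digits printed from compound 2 to compound 3 (within the scatter), so these two aryl groups on this oxygen cannot be told apart on this read-out. Compound 3 also shows a 3.5-fold higher number from compound 1 to compound 3 (0.54 log units; beyond the scatter), which matches a 3.5-fold higher number from compound 1 to compound 2 (0.54 log units; beyond the scatter), so both phenoxy compounds stand apart from the 4-cyanobenzyl compound, and none of the three goes against this. No supporting information on hand accounts for this result.

The compounds shown do not separate the effect of the oxygen link from that of the ring and its substituent, since 4-cyanobenzyl differs from both phenoxy groups in each of these. They also leave open how the number would respond to an amine or a carboxylic acid on the phenoxy ring, or to a simple alkyl chain on the oxygen in place of the aryl ring.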